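Adding a piperazine ester to the core of compound 1

The source may hold more compounds than are shown below. What is called first, only, known or untested is meant among the compounds shown, and "the series" means these compounds.

For the measured compounds named here, in an ADME assay on L6 cells (Rattus norvegicus) for cytotoxicity, read by resazurin assay, with a stated time of 72 h (a higher number here means a weaker inhibitor, a lower number a stronger inhibitor), compound 1 (`NC1CC2(N3CCCC3)CC(c3ccccc3)C1C(c1ccccc1)C2`) gives 38100 nM and holds the lower of the two numbers so far. Compound 2 (`CN1CCN(CCC(=O)N2CCC3(N(C)C)CC(c4ccccc4)C2C(c2ccccc2)C3)CC1`) stands higher at 128000 nM by more than the scatter. Compound 3 (`CN1CCN(CC(=O)OC2CC3(N4CCCC4)CC(c4ccccc4)C2C(c2ccccc2)C3)CC1`) keeps the core of compound 1 and carries (((4-methylpiperazin-1-yl)methyl)carbonyl)oxy in place of amino on a saturated ring carbon. Going by the values given here, no two measured compounds differ in one place, so no measured step guides this change. Among the compounds with values here, compound 2 is the only measured compound with a 4-methylpiperazin-1-yl group, and its 128000 nM is the sole hint available. A modest step towards a higher number, meaning a weaker inhibitor, is expected in this assay and estimated as a 1.6-fold higher number from compound 1 to compound 3 (0.20 log units; within the scatter) on that thin basis. For compound 3 the estimate is 60000 nM with an expected range from 20000 nM to 150000 nM for now.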

Compound 3, half-maximal inhibitory concentration: 24600 nM
For compound 3 the middle estimate is 2.4-fold (0.39 log units) above the measured one; the range from low to high includes it.
By their numbers in this assay, from the lowest: compounds 3 and 1 (each within the scatter of the next); then compound 2.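

In this assay, (((4-methylpiperazin-1-yl)methyl)carbonyl)oxy in place of amino on this saturated ring carbon gives a 1.5-fold lower number from compound 1 to compound 3 (0.19 log units; within the scatter) as the first step read at this position. The carbon therefore takes a group of 11 heavy atoms, including a six-membered non-aromatic ring, in place of a group of 1 heavy atom and loses the hydrogen-bond donor of the amino group, with no step beyond the scatter. No available measurement explains this result.

On these data alone, the step brings in the ester link and the 4-methylpiperazin-1-yl group together, and the part played by each in this assay remains open. A hydroxyl group or a plain acetyl ester on the same carbon would separate the two.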